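Cytotoxicity notes: from compound 3 to compound 4

This account rests on a few compounds, and the source may have more. Where it says the series, first, only, none or still open, it means among the compounds named here.

Measured so far in an ADME assay on J774 cells (Mus musculus) for cytotoxicity, read by MTT assay, with a stated time of 48 h, tested at 100 ug/mL; a lower number here means a stronger effect, a higher number a weaker effect of the compound at the concentration tested:
- compound 1 `O=C(N/N=C/c1cccc(Cl)c1)c1cnccn1` gives 100%
- compound 2 `CCOc1cccc(/C=N/NC(=O)c2cnccn2)c1` gives 71%
- compound 3 `O=C(N/N=C/c1cccc(O)c1)c1cnccn1` gives 100%

Compound 3 stands level with compound 1, the two together being the highest of the three numbers; compound 2 is the only one set apart, and its gap to compound 3 is beyond the scatter. The steps read no change at the digits printed from compound 1 to compound 3 (within the scatter), a number 29 percentage points lower from compound 1 to compound 2 (beyond the scatter) and a number 29 percentage points higher from compound 2 to compound 3 (beyond the scatter). Two of the three substituents on this aromatic carbon thus give the same high reading, and only the ethoxy group lowers it modestly.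

Compound 4 `O=C(N/N=C/c1cccc([N+](=O)[O-])c1)c1cnccn1` differs from compound 3 by nitro in place of hydroxy on an aromatic carbon. Among the compounds with values here, no measured step involves a nitro group, so the only guide is that the ring substituent changed the reading by nothing in one step and by a modest amount in the other. A step of at most that modest size is therefore expected, most likely none beyond the scatter, so that a number 5 percentage points lower from compound 3 to compound 4 (within the scatter) is the estimate. Compound 4 is expected to give 95%, within 65% to 100%.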

Compound 4, a percentage reported as activity, at one concentration (the size of the read-out at that concentration, not a potency): 85%
Beside the measured number, compound 4's estimate is 10 percentage points above it; low and high end bracket the measured number.
By their numbers in this assay, from the lowest: compound 2; then compound 4; then compounds 1 and 3 (each within the scatter of the next).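

Nitro on this aromatic carbon gives a third level in this assay, apart from both hydroxy (a number 15 percentage points lower from compound 3 to compound 4 (beyond the scatter)) and chloro (a number 15 percentage points lower from compound 1 to compound 4 (beyond the scatter)), and also apart from ethoxy (a number 14 percentage points higher from compound 2 to compound 4 (beyond the scatter)). The earlier compounds shown here showed only two levels, so the reading at this position is now seen to separate more finely, with nitro lying between the ethoxy compound and the pair carrying hydroxy and chloro. Nothing available accounts for this order of the substituents.

On these data alone, whether the reading follows any single feature of the substituent remains open, and an amine, a carboxylic acid or a longer chain on the oxygen at this carbon would test that. Also open, as far as these compounds go, is whether the same order holds with these groups elsewhere on the ring.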